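Swapping the Benzyl Group: From Compound 3 to Compound 4

A few compounds are considered here, and "the series" means these few. Any claim that something is new, unique, unknown or untested is made for them only; others in the source may bear on it.

Compound 3, `O=c1ccoc2cc(OCc3cn(Cc4ccc(Cl)cc4Cl)nn3)ccc12`, carries a 2,4-dichlorobenzyl group on the shared core. In a functional assay on HeLa cells (Homo sapiens) for cytotoxicity, read by MTT assay, with a stated time of 48 h (a lower number here means a stronger inhibitor, a higher number a weaker inhibitor), compound 3 gives 80600 nM. Of the two numbers reported in this assay, this is the higher one. Its nearest neighbour is compound 2, `O=c1ccoc2cc(OCc3cn(Cc4ccc([N+](=O)[O-])cc4)nn3)ccc12`, which in this assay gives 25700 nM, and the two are separated by a 3.1-fold higher number from compound 2 to compound 3 (0.50 log units; beyond the scatter). Compound 1, `Cc1ccc(Cn2cc(COc3ccc4c(=O)ccoc4c3)nn2)cc1`, returns only a limit of the assay in this assay, namely > 100000 nM, which is the limit of > 100000 nM in this assay, at which 1 of the 3 values shown sits. The step of an at least 1.2-fold lower number from compound 1 to compound 3 (0.09 log units; that floor lies within the scatter) therefore has a floor that sits within the scatter, while an at least 3.8-fold lower number from compound 1 to compound 2 (0.59 log units; beyond the scatter) is the clearer movement within this small set.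

Compound 4, `O=c1ccoc2cc(OCc3cn(Cc4ccc(Br)cc4)nn3)ccc12`, has not yet been measured. It differs from compound 3 as follows: 4-bromophenyl in place of 2,4-dichlorophenyl on a saturated chain carbon bound to an aromatic nitrogen. The measured steps that touch the same place are an at least 1.2-fold lower number from compound 1 to compound 3 (0.09 log units; that floor lies within the scatter) and a 3.1-fold higher number from compound 2 to compound 3 (0.50 log units; beyond the scatter); neither introduces a 4-bromophenyl, so they guide only loosely. Among the groups already tested at that position, 4-methylphenyl gives a limit and 4-nitrophenyl gives the lower of the two numbers. The expected step is a 1.2-fold higher number from compound 3 to compound 4 (0.09 log units; within the scatter), with no clear direction beyond the scatter. Compound 4 is thus estimated at 100000 nM, between 40000 nM and 250000 nM, with a real chance that only a limit is returned.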

Compound 4, half-maximal inhibitory concentration: > 100000 nM
Compound 4 gave a limit, no number; the forecaster's own chance of this, stated with the estimate: 45%; the middle value sits exactly at the limit.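

In this assay compound 4 returns only a limit, so 4-bromophenyl joins 4-methylphenyl on the saturated chain carbon bound to an aromatic nitrogen: the limit of > 100000 nM in this assay, at which 2 of the 4 values shown sit.

Bromo in place of nitro on an aromatic carbon gives an at least 3.8-fold higher number from compound 2 to compound 4 (0.59 log units; beyond the scatter), and compound 2 now holds a step beyond the scatter against each of the other three compounds, which makes it the strongest of this set. 4-bromophenyl in place of 2,4-dichlorophenyl gives an at least 1.2-fold higher number from compound 3 to compound 4 (0.09 log units; that floor lies within the scatter), so the size of this change stays unfixed and it may be small or larger, while the step between compound 1 and compound 4 cannot be read at all.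

The compounds shown leave open whether the lower number of compound 2 belongs to the nitro group alone or would also appear with an amine or a carboxylic acid on that aromatic carbon. They also leave open what a longer chain in place of the benzyl group would do at this place.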